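The source may report more compounds than this note shows. Statements on the series, on what has been measured and on what is new or still open speak of the compounds shown alone.

Within the data shown here, in a functional assay on cells (B cell, Homo sapiens) for inhibition, read by thymidine incorporation, with stated times of 30 min and 72 h (a lower number here means a stronger inhibitor, a higher number a weaker inhibitor), compound 2 `CCNC(=O)c1c(-c2ccccc2)c([C@H](C)Nc2ncnc(N)c2C#N)nc2ccc(F)cc12` gives 1.2 nM, the lower of the two numbers so far, and its gap to compound 1 `C[C@H](Nc1ncnc(N)c1C#N)c1nc2ccc(F)cc2c(-c2ccccn2)c1-c1ccccn1`, at 4.6 nM, lies beyond the scatter. Compound 3 `CCNC(=O)c1c(-c2ccccn2)c([C@H](C)Nc2ncnc(N)c2C#N)nc2ccc(F)cc12` has pyridin-2-yl in place of phenyl on an aromatic carbon. Among the measured compounds shown here, compound 1 also holds pyridin-2-yl, but no measured pair isolates this change. A small step towards a weaker inhibitor, within the scatter, is expected in this assay: a 1.5-fold higher number from compound 2 to compound 3 (0.18 log units; within the scatter). For compound 3 the estimated value is 1.8 nM, with an expected range of 0.6 nM to 5.5 nM.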

Compound 3, half-maximal inhibitory concentration: 1.6 nM
Estimate against measurement, compound 3: 1.1-fold (0.05 log units) above, and the stated range covers the measured number.
By their numbers in this assay, from the lowest: compounds 2 and 3 (each within the scatter of the next); then compound 1.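

In this assay, exchanging phenyl for pyridin-2-yl, ortho to the ethylcarbamoyl group, gives a 1.3-fold higher number from compound 2 to compound 3 (0.12 log units; within the scatter), so the two rings cannot be told apart here. Ethylcarbamoyl in place of pyridin-2-yl on an aromatic carbon gives a 2.9-fold lower number from compound 1 to compound 3 (0.46 log units; beyond the scatter), so the one step beyond the scatter belongs to that change and not to the ring swap. Nothing on hand gives a reason for either step. Going by these compounds, whether a non-aromatic group such as cyclohexyl at this carbon stays level with phenyl remains open. So does whether a longer amide chain or a carboxylic acid can replace ethylcarbamoyl.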